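The compounds below may be only part of what the source reports. "The series", "measured", "known", "first", "only" and "open" are said of these compounds alone.

Measured compounds:
compound 1 `CC1CCN(c2cc(C(F)(F)F)ccc2CNC(=O)C(C)c2ccc(NS(C)(=O)=O)c(F)c2)CC1` — 0.9 nM
compound 2 `CC(C(=O)NCc1ccc(C(F)(F)F)cc1C1CCCCC1)c1ccc(NS(C)(=O)=O)c(F)c1` — 0.6 nM
compound 3 `CC(C(=O)NCc1ccc(C(F)(F)F)cc1-c1cccc(Cl)c1)c1ccc(NS(C)(=O)=O)c(F)c1` — 1 nM

In an assay on CHO cells for antagonist activity at transient receptor potential cation channel subfamily V member 1 (Homo sapiens), read by FLIPR (on this read-out lower numbers stand for stronger inhibition and higher numbers for weaker inhibition), compound 3 gives 1 nM, the highest of the three numbers, yet its steps to the other two are both within the scatter: a 1.1-fold higher number from compound 1 to compound 3 (0.05 log units; within the scatter) and a 1.7-fold higher number from compound 2 to compound 3 (0.22 log units; within the scatter). The three measured compounds share one core and differ only in the group on one aromatic carbon, and the remaining step, a 1.5-fold lower number from compound 1 to compound 2 (0.18 log units; within the scatter), is likewise within the scatter.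

Compound 4 `CC(C(=O)NCc1ccc(C(F)(F)F)cc1-c1ccc(F)c(Cl)c1)c1ccc(NS(C)(=O)=O)c(F)c1` differs from compound 3 by fluoro in place of hydrogen on an aromatic carbon. Among the measured compounds shown here, no measured step adds or removes a single atom on the 3-chlorophenyl group; the measured steps exchange the whole group at that aromatic carbon, and all three lie within the scatter. They bear on the new step only in showing that changes at this part of the core have left the numbers flat so far. No step beyond the scatter is therefore expected in this assay.

Compound 4 is expected to give 1 nM, with a range of 0.4 nM to 2.5 nM. The expected step is no change at the digits printed from compound 3 to compound 4 (within the scatter).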

Compound 4, inhibition constant: 0.6 nM
Compound 4: the middle estimate sits 1.7-fold (0.22 log units) above what was measured; the range from low to high includes it.
By their numbers in this assay, from the lowest: compounds 2, 4, 1 and 3 (each within the scatter of the next).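

Fluoro in place of hydrogen on the 3-chlorophenyl group, ortho to a chloro group and para to a large group, is a single-atom change of a kind the earlier compounds did not offer, and in this assay it gives a 1.7-fold lower number from compound 3 to compound 4 (0.22 log units; within the scatter). The larger 3-chloro-4-fluorophenyl group also stays within the scatter of the other two groups at this aromatic carbon, with no change at the digits printed from compound 2 to compound 4 (within the scatter) and a 1.5-fold lower number from compound 1 to compound 4 (0.18 log units; within the scatter), so the flat picture now extends to a substituent added on the 3-chlorophenyl group itself. Nothing available explains this flatness.

Open, going by these compounds, is whether an amine or a carboxylic acid in place of the fluoro would leave the number within the scatter. Also open, on these data alone, is whether the fluoro gives the same result on a phenyl group lacking the chloro group.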